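The compounds below may be only part of what the source reports. "The series", "measured", "known", "first", "only" and "open" are said of these compounds alone.

Compound 1 `CCC(CC)(c1ccc(OCC(O)C(C)(C)C)c(C)c1)c1ccc(C(=O)N[C@H](CO)CCO)n1C`: 200 nM
Compound 2 `CCn1c(C(=O)N[C@@H](C)CO)ccc1C(CC)(CC)c1ccc(OCC(O)C(C)(C)C)c(C)c1`: 1.06 nM

Both numbers come from an assay on HL-60 cells for agonist activity at vitamin D3 receptor (Homo sapiens), with a stated time of 96 h; on this read-out higher numbers stand for an effect only at larger amounts of compound and lower numbers for an effect already at smaller amounts. Compound 2 gives the lower of the two numbers, and the gap to compound 1 lies well beyond the usual scatter of this assay. Compound 3 `CCn1c(C(=O)N[C@H](CO)CCO)ccc1C(CC)(CC)c1ccc(OCC(O)C(C)(C)C)c(C)c1` has not yet been measured. It differs from compound 2 in one place: hydroxymethyl in place of hydrogen on a saturated chain carbon, two bonds along the chain from an amide-type nitrogen. Within the data shown here, no measured pair shows this change on its own, so its effect is not known directly. Compound 3 shares its amide side chain with compound 1, which carries a different group on the core nitrogen, so the value of compound 1, 200 nM, cannot be attributed to the side chain alone. Still, the number for compound 3 is expected to rise beyond the scatter, by about a 9.4-fold higher number from compound 2 to compound 3 (0.97 log units; beyond the scatter), while staying well short of compound 1. Compound 3 is estimated at 10 nM, within a range of 2 nM to 80 nM.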

Compound 3, half-maximal effective concentration: 110 nM
Compound 3: middle estimate off by 11-fold (1.04 log units), on the low side; measured number outside the range, above it.
By their numbers in this assay, from the lowest: compound 2; then compounds 3 and 1 (each within the scatter of the next).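

In this assay, among these compounds, hydroxymethyl in place of hydrogen on a saturated chain carbon, two bonds along the chain from an amide-type nitrogen, gives a 100-fold higher number from compound 2 to compound 3 (2.02 log units; beyond the scatter); this is the first direct view of this change alone, and the step is large. With this side chain in place, methyl in place of hydrogen on a saturated chain carbon bound to an aromatic nitrogen gives a 1.8-fold lower number from compound 1 to compound 3 (0.26 log units; within the scatter), so this second change does not separate the two compounds beyond the scatter. No measurement at hand explains the large step.

The compounds shown leave open how an ethyl or a 2-aminoethyl would behave in place of the 2-hydroxyethyl. They also leave open whether the change on the aromatic nitrogen would stay as small with the side chain of compound 2.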